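A few compounds are considered here, and "the series" means these few. Any claim that something is new, unique, unknown or untested is made for them only; others in the source may bear on it.

In a functional assay on A549 cells (Homo sapiens) for inhibition, read by CCK-8 assay, with a stated time of 72 h, tested at 8 uM (on this read-out lower numbers stand for less inhibition of growth and higher numbers for more inhibition of growth at the one concentration tested), compound 1 `Nc1ccccc1NC(=O)/C=C/c1ccc(CSc2cccc(F)c2)cc1` gives 56.6%. Two relatives built on a different core are compound 2 `COc1ccc(SCc2ccc(C(=O)Nc3ccccc3N)cc2)cc1`, at 70.7%, and compound 3 `Nc1ccccc1NC(=O)c1ccc(CSc2cccc(F)c2)cc1`, at 72.7%. Compound 1 thus holds the lowest of the three numbers, and its gap to each of the other two lies beyond the usual scatter.

The next compound, compound 4 `Nc1ccccc1NC(=O)/C=C/c1ccc(CSc2cccc3ccccc23)cc1`, keeps the core of compound 1 and changes only the group on the sulfur: naphthalen-1-yl in place of 3-fluorophenyl on a sulfur. For the measured compounds named here, only one measured step touches this place, and it shows a number 2 percentage points higher from compound 2 to compound 3 (within the scatter), with 3-fluorophenyl in place of 4-methoxyphenyl on a sulfur. That step is small, but it was measured on the other core and involves no naphthalen-1-yl, so it is only weak guidance. Going by that single step, no change beyond the scatter is expected in this assay, in either direction. The expected result is a number 1.6 percentage points lower from compound 1 to compound 4 (within the scatter). For compound 4 the estimated value is 55%, with an expected range from 38% to 72%.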

Compound 4, percent growth inhibition at one concentration: 71.2%
Compound 4: middle estimate off by 16.2 percentage points, on the low side, within the range that was stated.
By their numbers in this assay, from the lowest: compound 1; then compounds 2, 4 and 3 (each within the scatter of the next).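

In this assay, the group on the sulfur clearly counts on the core of compound 1: the swap to naphthalen-1-yl gives a number 14.6 percentage points higher from compound 1 to compound 4 (beyond the scatter). For the compounds shown here, the only earlier step at this place, a number 2 percentage points higher from compound 2 to compound 3 (within the scatter), was a swap between two other groups on a different core, so it could not show that this position is able to move the number this far. The change replaces one six-membered aromatic ring of 7 heavy atoms with two such rings of 10 heavy atoms, but nothing available here explains why the number rises.

Going by these compounds, it remains open whether naphthalen-1-yl would have a similar effect on the core of compound 3. On these data alone, it is also open how a group carrying an amine or a carboxylic acid would behave on this sulfur.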